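A few compounds are considered here, and "the series" means these few. Any claim that something is new, unique, unknown or untested is made for them only; others in the source may bear on it.

In a functional assay on RBL-2H3 cells (Rattus norvegicus) for inhibition, with stated times of 30 min and 1 h (on this read-out higher numbers stand for weaker inhibition and lower numbers for stronger inhibition), compound 1 `COc1ccc(CN(CCN(C)C)c2ccccc2)cc1` gives 243 nM and compound 2 `COc1ccc(CN(CCN(C)C)c2ccc(Cl)cn2)cc1` gives 19.2 nM as the lower of the two numbers. Among the measured compounds shown here, compound 3 `COc1ccc(CN(CCN(C)C)c2ccc(N)cn2)cc1` differs from compound 2 by amino in place of chloro on an aromatic carbon as its one change, amino in place of chloro on an aromatic carbon. For the measured compounds named here, the only measured step bearing on this is a 13-fold lower number from compound 1 to compound 2 (1.10 log units; beyond the scatter) and it is large, but it brought in the chloro and the ring nitrogen together, so the data cannot separate them. Part of that gain is expected to be lost in this assay with a moderately higher number. The estimate means a 4.2-fold higher number from compound 2 to compound 3 (0.62 log units; beyond the scatter) as the expected step. Compound 3 is expected near 80 nM within an estimated range of 20 nM to 320 nM in this assay.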

Compound 3, half-maximal inhibitory concentration: 2110 nM
Compound 3: middle estimate off by 26-fold (1.42 log units), on the low side; measured number outside the range, above it.
By their numbers in this assay, from the lowest: compound 2; then compound 1; then compound 3.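

In this assay the group at this place proves decisive: amino in place of chloro gives a 110-fold higher number from compound 2 to compound 3 (2.04 log units; beyond the scatter) and removes all of the gain seen with 5-chloropyridin-2-yl. The 5-aminopyridin-2-yl group in place of phenyl gives an 8.7-fold higher number from compound 1 to compound 3 (0.94 log units; beyond the scatter) and so falls behind the plain phenyl compound, which shows that the ring nitrogen does not secure the gain when amino stands at this place. The compounds shown leave open how pyridin-2-yl without a further group would stand, and whether bromo or methoxy here would follow chloro or amino. Nothing available explains the size of this change.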